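From 2,4-dichlorophenyl to 2-bromophenyl: working notes

The source may hold more compounds than are shown below. What is called first, only, known or untested is meant among the compounds shown, and "the series" means these compounds.

Three measured entries share one core and one propyl ether chain and differ in the aryl group: compound 1 (`NC1=NC2(CCOCC2)N(OCCCOc2cccc(Cl)c2Cl)C(N)=N1`), compound 2 (`NC1=NC2(CCOCC2)N(OCCCOc2ccc(F)cc2)C(N)=N1`) and compound 3 (`NC1=NC2(CCOCC2)N(OCCCOc2ccc(Cl)cc2Cl)C(N)=N1`). Among the compounds with values here, in a functional assay on MDA-MB-231 cells (Homo sapiens) for antiproliferative activity, read by MTT assay, with a stated time of 72 h (a lower number here means a stronger inhibitor, a higher number a weaker inhibitor), compound 1 gives 140 nM, the only number available so far. For compound 2 the entry reads "not determined" (no result reported). For compound 3 the entry reads "not determined" (no result reported), so compound 3 has no place on the numerical scale and offers no value to step from. Compound 2 is the one further entry in the same state.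

The next entry is compound 4 (`NC1=NC2(CCOCC2)N(OCCCOc2ccccc2Br)C(N)=N1`). The change from compound 3 is 2-bromophenyl in place of 2,4-dichlorophenyl on an oxygen on a saturated carbon. Within the data shown here, no step between two measured compounds is available, so the series shows nothing about how much the aryl group matters in this assay. No direction can be argued, and no shift beyond the usual scatter is expected from the one anchor, compound 1 at 140 nM. With a single anchor, the range is kept wide. The expected value for compound 4 is 150 nM, with an estimated range of 40 nM to 550 nM.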

Compound 4, half-maximal inhibitory concentration: 910 nM
Compound 4: the middle estimate sits 6.1-fold (0.78 log units) below what was measured, outside the stated range (above it).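

In this assay, within the data shown here, the aryl group on the propyl ether chain proves to matter: the change of aryl group gives a 6.5-fold higher number from compound 1 to compound 4 (0.81 log units; beyond the scatter), the first measured step and one that lies beyond the scatter. Going by these compounds, compound 2 and compound 3 carry no number, so the steps that involve them, including the step from compound 3 to compound 4, cannot be read, and the effect of leaving 2,4-dichlorophenyl remains unknown. No measurement at hand accounts for the size of the step from the 2,3-dichlorophenyl compound to the 2-bromophenyl compound.

This single step changes both the halogen and the number of halogens on the ring, and the compounds shown do not separate the two changes; a 2-chlorophenyl group would bear on that question. Also open, on these data alone, is how the series would read in this assay with a plain phenyl group, with an amine or a carboxylic acid on the ring, or with a longer chain in place of the propyl chain.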